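Adding a morpholine-bearing arm to a thiazolidinedione core

The source may hold more compounds than are shown below. What is called first, only, known or untested is meant among the compounds shown, and "the series" means these compounds.

Compound 1 `COc1cc(-c2nc3cc(/C=C4\SC(=O)NC4=O)ccc3[nH]2)cc(OC)c1OC`: 3120 nM
Compound 2 `COc1ccc(-c2nc3cc(/C=C4\SC(=O)NC4=O)ccc3[nH]2)cc1OC`: 2430 nM

In a functional assay on HT-1080 cells (Homo sapiens) for inhibition, read by MTT assay, with a stated time of 48 h (on this read-out lower numbers stand for stronger inhibition and higher numbers for weaker inhibition), compound 1 gives 3120 nM, the higher of the two numbers, with compound 2 close by at 2430 nM. Among the compounds with values here, the only measured step, a 1.3-fold lower number from compound 1 to compound 2 (0.11 log units; within the scatter), concerns a methoxy group on the aromatic ring and says nothing about the change ahead. Compound 3 `COc1cc(-c2nc3cc(/C=C4\SC(=O)N(CC(=O)N5CCOCC5)C4=O)ccc3[nH]2)cc(OC)c1OC` differs from compound 1 by ((morpholin-4-yl)carbonyl)methyl in place of hydrogen on an amide-type nitrogen in a ring. Within the data shown here, no measured step touches this nitrogen, so no direction can be expected beyond the scatter. Compound 3 is therefore estimated at 3000 nM (range 800 nM to 12000 nM), a step of a 1.0-fold lower number from compound 1 to compound 3 (0.02 log units; within the scatter).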

Compound 3, half-maximal inhibitory concentration: 1680 nM
Compound 3: the middle estimate sits 1.8-fold (0.25 log units) above what was measured; low and high end bracket the measured number.
By their numbers in this assay, from the lowest: compounds 3, 2 and 1 (each within the scatter of the next).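

In this assay, putting ((morpholin-4-yl)carbonyl)methyl on the amide-type nitrogen gives a 1.9-fold lower number from compound 1 to compound 3 (0.27 log units; within the scatter). The amide hydrogen of compound 1 can therefore be replaced by this arm of 9 heavy atoms, with its six-membered ring, without a shift beyond the scatter. Nothing measured here explains this result.

Still open, on these data alone, is how this nitrogen responds to a plain methyl, or to a longer chain ending in an amine or a carboxylic acid. Also open, as far as these compounds go, is whether the same arm gives a similar result on compound 2.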